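Pyridinyl amide in place of acetyl on a thiazole alkyne

The source may report more compounds than this note shows. Statements on the series, on what has been measured and on what is new or still open speak of the compounds shown alone.

Measured compounds:
compound 1 `O=C1NCCc2nc(C#Cc3ccccc3F)sc21` — 1500 nM
compound 2 `CC(=O)N1CCc2nc(C#Cc3ccccc3)sc2C1` — > 10000 nM

In an assay on HEK293 cells for positive allosteric modulation of metabotropic glutamate receptor 5 (Homo sapiens), read by FLIPR, with a stated time of 1 h (on this read-out higher numbers stand for an effect only at larger amounts of compound and lower numbers for an effect already at smaller amounts), compound 1 gives 1500 nM. Compound 2 reaches only a limit of this assay, > 10000 nM, and so carries no number of its own. That is the limit of > 10000 nM in this assay, at which 1 of the 2 values shown sits. For the measured compounds named here, compound 2 thus stands at the weak end of what has been measured here, with compound 1 the only compound given a number.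

Compound 3 `Cc1cccc(C(=O)N2CCc3nc(C#Cc4ccccc4)sc3C2)n1` differs from compound 2 in one place: 6-methylpyridin-2-yl in place of methyl on a carbonyl carbon. Going by the values given here, no measured pair shows this change on its own, so the size of the step is not known from the data. The expectation is a gain in this assay beyond the scatter, with compound 3 estimated at 500 nM and a range from 100 nM to 5000 nM. This expected step is an at least 20-fold lower number from compound 2 to compound 3 (1.30 log units; beyond the scatter).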

Compound 3, half-maximal effective concentration: 160 nM
Compound 3: the middle estimate sits 3.1-fold (0.49 log units) above what was measured; measured number inside the range.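

In this assay, the carbonyl carbon on the amide-type nitrogen in a ring proves to be a place where the group makes a large difference: 6-methylpyridin-2-yl in place of methyl gives an at least 62-fold lower number from compound 2 to compound 3 (1.79 log units; beyond the scatter) and lies beyond the scatter. For the compounds shown here, the earlier compounds offered no pair that differed here, so this is the first reading of the position. The step gives only a lower bound on the size of the change, since compound 2 has a limit rather than a number: the limit of > 10000 nM in this assay, at which 1 of the 3 values shown sits.

The compounds shown leave open whether the gain rests on the ring, its nitrogen or its methyl, which unsubstituted phenyl or pyridin-2-yl on the same carbonyl carbon would help to separate. They also leave open whether a ring is needed at all, which a longer chain such as butyl could test.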